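A few compounds are considered here, and "the series" means these few. Any claim that something is new, unique, unknown or untested is made for them only; others in the source may bear on it.

Working notes on the series.

The shared core carries, on a saturated chain carbon two bonds along the chain from two aromatic carbons and an oxygen on a saturated carbon, a variable group. Compound 1 `COc1ccc(C(O)(Cc2ccc(C)cc2)c2cccc3ccccc23)c(OC)c1OC` carries 4-methylphenyl there, compound 2 `C=CCC(O)(c1ccc(OC)c(OC)c1OC)c1cccc2ccccc12` vinyl, compound 3 `COc1ccc(C(O)(Cc2ccc(F)cc2)c2cccc3ccccc23)c(OC)c1OC` 4-fluorophenyl, and compound 4 `COc1ccc(C(O)(C/C=C\c2ccccc2)c2cccc3ccccc23)c(OC)c1OC` 2-phenylethenyl. In a functional assay on MCF7 cells (Homo sapiens) for inhibition, read by sulforhodamine B assay, with a stated time of 48 h (a lower number here means a stronger inhibitor, a higher number a weaker inhibitor), compound 1 gives only a limit, > 20000 nM. In this assay compound 2 likewise gives only a limit, > 20000 nM. In this assay, going by the values given here, compound 3 gives 7560 nM, the only number in the set; the other two values sit at the limit of > 20000 nM in this assay, at which 2 of the 3 values shown sit.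

The step to compound 4 is 2-phenylethenyl in place of 4-fluorophenyl on a saturated chain carbon, two bonds along the chain from two aromatic carbons and an oxygen on a saturated carbon; cut one bond further out, it reads 4-fluorobenzyl to 3-phenylprop-2-en-1-yl. Both steps into compound 3 bear on it: an at least 2.6-fold lower number from compound 1 to compound 3 (0.42 log units; beyond the scatter) and an at least 2.6-fold lower number from compound 2 to compound 3 (0.42 log units; beyond the scatter). Compound 2, with vinyl alone, sits at the limit, while compound 3 carries the aromatic ring directly. Compound 4 keeps the ring but through a double bond, so no step beyond the scatter is expected, a 1.2-fold higher number from compound 3 to compound 4 (0.08 log units; within the scatter). Compound 4 is estimated at 9000 nM, between 3000 nM and 20000 nM.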

Compound 4, half-maximal inhibitory concentration: 10200 nM
For compound 4 the middle estimate is 1.1-fold (0.05 log units) below the measured one; measured number inside the range.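

In this assay, replacing 4-fluorophenyl gives a 1.3-fold higher number from compound 3 to compound 4 (0.13 log units; within the scatter), so 2-phenylethenyl and 4-fluorophenyl cannot be told apart at this position. Compound 4 carries no fluorine yet still gives a number, so a measured value here does not depend on fluorine, though the comparison with the limit compounds stays weak, with an at least 1.9-fold lower number from compound 2 to compound 4 (0.29 log units; that floor lies within the scatter) and an at least 1.9-fold lower number from compound 1 to compound 4 (0.29 log units; that floor lies within the scatter). Both of these floors lie within the scatter and rest on limits rather than numbers: the limit of > 20000 nM in this assay, at which 2 of the 4 values shown sit.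

On these data alone, the true values of compound 1 and compound 2 remain unknown, so the full size of these two steps cannot be read. Also open, as far as these compounds go, is whether an amine or a carboxylic acid at this position would give a number in this assay.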